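The source may report more compounds than this note shows. Statements on the series, on what has been measured and on what is new or still open speak of the compounds shown alone.

Measured so far in a functional assay on OVCAR-8 cells (Homo sapiens) for inhibition; a lower number here means a stronger inhibitor of growth, a higher number a weaker inhibitor of growth:
Compound 1 `COc1cc(/C=C/C(=O)c2cccc(-n3cc(-c4ccc(Cl)cc4)[nH]c3=O)c2)cc(OC)c1OC` gives 3850 nM.
Compound 2 `COc1cc(/C=C/C(=O)c2cccc(-n3cc(-c4ccccc4)[nH]c3=O)c2)ccc1O` gives 4110 nM.
Compound 3 `O=C(/C=C/c1cccc(O)c1)c1cccc(-n2cc(-c3ccccc3)[nH]c2=O)c1` gives 2800 nM.

The three numbers sit close together: the gaps from compound 1 to compound 2 and from compound 1 to compound 3 both fall within the scatter, so compound 1 cannot be set apart from either of the others on these data. Among the compounds with values here, the only step measured within the set, a 1.5-fold lower number from compound 2 to compound 3 (0.17 log units; within the scatter), concerns the aryl on the enone side and also stays within the scatter.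

Compound 4 `COc1cc(/C=C/C(=O)c2cccc(-n3cc(-c4ccccc4)[nH]c3=O)c2)cc(OC)c1OC` differs from compound 1 by hydrogen in place of chloro on an aromatic carbon. Within the data shown here, no measured pair shows this change; the step from compound 2 to compound 3 touches a different part of the molecule and does not bear on it. Among the measured compounds shown here, nothing among the measured compounds points to a shift beyond the scatter in this assay in either direction, and the whole set so far spans a narrow band.

The estimate for compound 4 is therefore about 3500 nM, with a range of 1500 nM to 8000 nM. That corresponds to an expected step of a 1.1-fold lower number from compound 1 to compound 4 (0.04 log units; within the scatter), which is no change beyond the scatter.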

Compound 4, concentration for 50% growth inhibition: 1620 nM
Compound 4: the middle estimate sits 2.2-fold (0.33 log units) above what was measured, within the range that was stated.
By their numbers in this assay, from the lowest: compounds 4, 3, 1 and 2 (each within the scatter of the next, the first and the last beyond it).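

In this assay, within the data shown here, hydrogen in place of chloro gives the first step beyond the scatter, with a 2.4-fold lower number from compound 1 to compound 4 (0.38 log units; beyond the scatter) being a modest change. Among these compounds, the position on the aromatic ring para to a large group therefore registers in this read-out, with phenyl giving the lower number than 4-chlorophenyl, whereas the only earlier step, a 1.5-fold lower number from compound 2 to compound 3 (0.17 log units; within the scatter) at the enone-side aryl, stayed within the scatter. No measurement at hand accounts for this difference.

From the compounds shown here alone, the reading rests on a single pair, so it remains open whether fluoro, methoxy or an amine at this position would follow chloro or hydrogen. Going by these compounds, it also remains open whether the same step would appear with the 3-hydroxyphenyl of compound 3 in place of the enone-side aryl of compound 4.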